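This account rests on a few compounds, and the source may have more. Where it says the series, first, only, none or still open, it means among the compounds named here.

Compound 1 `CCn1nc(CC(=O)Nc2ccc(OC(F)(F)F)c(Cl)c2)c2ccccc2c1=O` and compound 2 `CCOc1cc2nn(Cc3nn(CC(=O)O)c(=O)c4ccccc34)cc2cc1Cl` were both tested in a functional assay on CHO cells for antagonist activity at sphingosine 1-phosphate receptor 2 (Homo sapiens), read by GTPgammaS binding; on this read-out higher numbers stand for weaker inhibition and lower numbers for stronger inhibition. In this assay compound 1 gives 473 nM, the higher of the two numbers. In this assay compound 2 gives 113 nM, and the gap between that number and the number of compound 1 lies beyond the usual scatter. Among the compounds with values here, the two structures differ in several places at once, so no single step connects them. Compound 3 `O=C(Cc1nn(CC(=O)N2CCOCC2)c(=O)c2ccccc12)Nc1ccc(OC(F)(F)F)c(Cl)c1` differs from compound 1 in one place: (morpholin-4-yl)carbonyl in place of methyl on a saturated chain carbon bound to an aromatic nitrogen. Within the data shown here, no step of this kind between measured compounds is available, so the size of the change in this assay cannot be read from a neighbouring pair. For compound 3 the expected step of a 1.6-fold lower number from compound 1 to compound 3 (0.20 log units; within the scatter) is small, with a wide range in either direction. The expected number for compound 3 in this assay is 300 nM, estimated to fall between 80 nM and 1200 nM.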

Compound 3, half-maximal inhibitory concentration: 103 nM
Compound 3: the middle estimate sits 2.9-fold (0.46 log units) above what was measured; measured number inside the range.
By their numbers in this assay, from the lowest: compounds 3 and 2 (each within the scatter of the next); then compound 1.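

Replacing methyl with (morpholin-4-yl)carbonyl on a saturated chain carbon bound to an aromatic nitrogen gives a 4.6-fold lower number from compound 1 to compound 3 (0.66 log units; beyond the scatter) in this assay. Within the data shown here, this is the first step read at this place, and it shows that the number there responds to the change. The much larger group, with its six-membered non-aromatic ring and carbonyl, goes with stronger inhibition rather than weaker. Nothing measured here explains the step.

The compounds shown leave open whether the morpholine ring or the carbonyl goes with the lower number, since neither a piperidin-1-ylcarbonyl group nor a plain primary amide at this place appears among them. As far as these compounds go, with a single pair, it also remains open whether the same change would give a similar step on another core.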